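This account rests on a few compounds, and the source may have more. Where it says the series, first, only, none or still open, it means among the compounds named here.

In a functional assay on HCT-116 cells (Homo sapiens) for antiproliferative activity (on this read-out lower numbers stand for stronger inhibition and higher numbers for weaker inhibition), compound 1 `COc1ccc(-c2snnc2-c2cc(OC)c(OC)c(OC)c2)cc1[N+](=O)[O-]` gives 30.2 nM and compound 2 `COc1ccc(-c2snnc2-c2cc(OC)c(OC)c(OC)c2)cc1OC` gives 50.9 nM. Compound 3 `COc1cc(-c2nnsc2-c2ccc([N+](=O)[O-])cc2)cc(OC)c1OC` is reported as > 1000 nM, which is a limit of the assay and not a number. Compound 4 `COc1ccc(-c2snnc2-c2cc(OC)c(OC)c(OC)c2)cc1` has not yet been measured. It differs from compound 3 by methoxy in place of nitro on an aromatic carbon, para to a large group.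

The same exchange has been measured once, on a different background, as a 1.7-fold higher number from compound 1 to compound 2 (0.23 log units; within the scatter). That step stays within the scatter, but it is a poor guide to size here. Compound 2, at 50.9 nM, and compound 1, at 30.2 nM, both keep a methoxy on the aromatic ring that carries the change, as compound 4 does, whereas compound 3 has none on it. On that basis, compound 4 is expected to read in the range of these two compounds rather than near the limit seen for compound 3, so a large step towards stronger inhibition is expected in this assay. The estimated step is an at least 12-fold lower number from compound 3 to compound 4 (1.09 log units; beyond the scatter). Compound 4 is estimated at 80 nM, with an expected range from 15 nM to 500 nM.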

Compound 4, half-maximal inhibitory concentration: 25 nM
For compound 4 the middle estimate is 3.2-fold (0.51 log units) above the measured one; low and high end bracket the measured number.
By their numbers in this assay, from the lowest: compounds 4, 1 and 2 (each within the scatter of the next, the first and the last beyond it). At a limit, above all of these: compound 3.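

In this assay, methoxy in place of nitro on an aromatic carbon, para to a large group, gives an at least 40-fold lower number from compound 3 to compound 4 (1.60 log units; beyond the scatter) and so differs sharply from the same exchange on the other core: the same change on two cores in this assay, a 1.7-fold higher number (0.23 log units; within the scatter) from compound 1 to compound 2 and an at least 40-fold lower number (1.60 log units; beyond the scatter) from compound 3 to compound 4, at least 67-fold (1.82 log units) apart, beyond the scatter of two such steps.
The reading of compound 3 is a limit and not a number: the limit of > 1000 nM in this assay, at which 1 of the 4 values shown sits.
With methoxy at this position, the further group on the ring of compound 1 and compound 2 is not needed for a low reading: hydrogen in place of methoxy gives a 2.0-fold lower number from compound 2 to compound 4 (0.31 log units; beyond the scatter) as a modest step, and hydrogen in place of nitro gives a 1.2-fold lower number from compound 1 to compound 4 (0.08 log units; within the scatter) without a step beyond the scatter.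

Whether methoxy itself is required at this position stays open, as the reading with a hydroxyl, an amine or a longer chain such as ethoxy there is unknown from the compounds shown.
Also open, from the compounds shown here alone, is how far the further site on this ring tolerates other groups, such as a carboxylic acid or an amine.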